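A few compounds are considered here, and "the series" means these few. Any claim that something is new, unique, unknown or untested is made for them only; others in the source may bear on it.

In a physicochemical assay for lipophilicity, read by HPLC, at pH 7.4 (on this read-out higher numbers stand for higher lipophilicity and lower numbers for lower lipophilicity), compound 1 `CCC/N=C1\S/C(=C\c2ccc(O)cn2)C(=O)N1c1ccccc1C` gives 3. Compound 2 `Cc1ccccc1N1C(=O)/C(=C/c2ccc(O)c(Cl)c2)S/C1=N\CCO` gives 1.9, so compound 1 holds the higher of the two actual numbers, with a gap beyond the scatter. Compound 3 `CCC/N=C1\S/C(=C\c2ccc(O)c(Cl)c2)C(=O)N1C(C)C` is reported only as a limit, > 4.3.

The account now turns to compound 4 `CCC/N=C1\S/C(=C\c2ccc(O)c(C)c2)C(=O)N1c1ccccc1C`, which has not yet been measured. Its difference from compound 1 is 4-hydroxy-3-methylphenyl in place of 5-hydroxypyridin-2-yl on a double-bonded chain carbon bound to a double-bonded ring carbon. Within the data shown here, no measured pair isolates this exchange, so any expectation is loose. Compound 2 and compound 3 both carry a six-membered aromatic ring of carbon only at that place, yet their readings lie far apart, so that ring alone does not settle the value. Starting from compound 1 at 3, with the rest of the structure unchanged, an upward move in this assay is expected, leaning on compound 3 rather than on compound 2. The expected size is a number 1.10 log units higher from compound 1 to compound 4 (beyond the scatter), which would lie beyond the scatter. For compound 4 the estimate is 4.1, with an expected range from 3.5 to 4.7.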

Compound 4, distribution coefficient: 3.8
For compound 4 the middle estimate is 0.30 log units above the measured one; low and high end bracket the measured number.
By their numbers in this assay, from the lowest: compound 2; then compound 1; then compound 4. At a limit, above all of these: compound 3.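

In this assay, putting 4-hydroxy-3-methylphenyl in place of 5-hydroxypyridin-2-yl on a double-bonded chain carbon bound to a double-bonded ring carbon gives a number 0.80 log units higher from compound 1 to compound 4 (beyond the scatter). Among these compounds, this is the first step in the set that isolates a single place, and it shows that the reading moves with this exchange alone while the rest of the structure stays the same, something the earlier compounds, which differ from one another in more than one place, could not show. Compound 3 remains a limit and not a number, and no step to it can be read: the limit of > 4.3 in this assay, at which 1 of the 4 values shown sits.

As far as these compounds go, what stays open is how much of the step belongs to the loss of the ring nitrogen and how much to the added methyl, as the two change together here. From the compounds shown here alone, a plain 4-hydroxyphenyl group at this place would separate those two parts, and the direction and size of the step with an amine or a carboxylic acid on that ring also remain open.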